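A Hydroxycyclobutyl Swap Carried Onto a Second Core

A few compounds are considered here, and "the series" means these few. Any claim that something is new, unique, unknown or untested is made for them only; others in the source may bear on it.

Compound 1 `COc1cc(C(=O)N2CC(C)OCC2CCO)cc2nc(NCc3cc(Cl)ccn3)oc12` and compound 2 `COc1cc(C(=O)N2CC(C)OCC2C2CC(O)C2)cc2nc(NCc3cc(Cl)ccn3)oc12` share one core and differ only in 3-hydroxycyclobutyl in place of 2-hydroxyethyl on a saturated ring carbon. In an assay on isolated protein for inhibition of thyroid hormone receptor beta (Homo sapiens), read by fluorescence, with a stated time of 30 min (a lower number here means a stronger inhibitor, a higher number a weaker inhibitor), compound 1 gives 29 nM, and compound 2 gives 8 nM, a step of a 3.6-fold lower number from compound 1 to compound 2 (0.56 log units; beyond the scatter). Compound 3 `COc1cc(C(=O)N2CC(C)OCC2CCO)cn2nc(NCc3cccc(Cl)c3)nc12` is built on a different core; how the two cores differ is not broken down here. In this assay compound 3 gives 52 nM, which stands within the scatter of compound 1. Compound 4 `COc1cc(C(=O)N2CC(C)OCC2C2CC(O)C2)cn2nc(NCc3cccc(Cl)c3)nc12` carries the same change on the core of compound 3, (3-hydroxycyclobutyl in place of 2-hydroxyethyl on a saturated ring carbon). Resting on a 3.6-fold lower number from compound 1 to compound 2 (0.56 log units; beyond the scatter), the only earlier instance of this change, the expected step for compound 4 is a 3.3-fold lower number from compound 3 to compound 4 (0.51 log units; beyond the scatter). Compound 4 is therefore estimated at 16 nM, with a likely range from 6 nM to 40 nM.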

Compound 4, half-maximal inhibitory concentration: 9.4 nM
Estimate against measurement, compound 4: 1.7-fold (0.23 log units) above; the measured number falls inside the stated range.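

In this assay, 3-hydroxycyclobutyl in place of 2-hydroxyethyl on the core of compound 3 gives a 5.5-fold lower number from compound 3 to compound 4 (0.74 log units; beyond the scatter). The change therefore carries across these two cores with no difference in step size beyond the scatter: the same change on two cores in this assay, a 3.6-fold lower number (0.56 log units; beyond the scatter) from compound 1 to compound 2 and a 5.5-fold lower number (0.74 log units; beyond the scatter) from compound 3 to compound 4, 1.5-fold (0.18 log units) apart, within the scatter of two such steps. Within the data shown here, this rests on only two matched pairs in a single assay, so it does not show that the step would hold on any further core, nor does it explain why the step arises.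

The compounds shown leave open how a longer chain such as 3-hydroxypropyl or an amine would compare at this saturated ring carbon. They also leave open what a plain cyclobutyl, without its hydroxyl, would give on either core.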